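Cytotoxicity limits and a benzoyl-for-benzyl step

This account rests on a few compounds, and the source may have more. Where it says the series, first, only, none or still open, it means among the compounds named here.

compound 1 `CCC1(Cc2ccccc2)OS(=O)(=O)C=C1OCC1CCCCC1`: >= 200000 nM, a limit only
compound 2 `CCC1(Cc2ccccc2)OS(=O)(=O)C=C1OCCc1ccccc1`: >= 20000 nM, a limit only
compound 3 `CCC1(Cc2ccccc2)OS(=O)(=O)C=C1OCc1ccccc1`: >= 50000 nM, a limit only

In an ADME assay on HEL cells (Homo sapiens) for cytotoxicity, with a stated time of 3 days (a higher number here means that more compound is tolerated, a lower number that less compound is tolerated), compound 3 stands at a limit, not a number. Every value in the set is such a limit, so the steps a step that the two limits leave unreadable from compound 1 to compound 2, a step that the two limits leave unreadable from compound 1 to compound 3 and a step that the two limits leave unreadable from compound 2 to compound 3 have no readable size, as the limit of >= 20000 nM in this assay, at which 1 of the 3 values shown sits, the limit of >= 200000 nM in this assay, at which 1 of the 3 values shown sits, and the limit of >= 50000 nM in this assay, at which 1 of the 3 values shown sits, show. Compound 4 `CCC1(Cc2ccccc2)OS(=O)(=O)C=C1OC(=O)c1ccccc1` carries benzoyl in place of benzyl on an oxygen on an unsaturated carbon. Among the compounds with values here, no measured step shares this change, and the three unreadable steps give no direction to expect. In this assay compound 4 is therefore estimated at 50000 nM, between 10000 nM and 200000 nM. The expected step is a number no higher from compound 3 to compound 4 (the limit leaves the size open), and a further limit rather than a number is the likelier outcome.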

Compound 4, minimum cytotoxic concentration: > 400000 nM
Compound 4: a limit, no number (the forecaster's own chance of this, stated with the estimate: 60%); at least 8.0-fold (0.90 log units) between middle value and limit.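

In this assay compound 4 gives > 400000 nM as a limit, not a number. Within the data shown here, compound 1, compound 2 and compound 3 also stand at limits, so no step to compound 4 can be read. The compounds shown leave open whether benzoyl in place of benzyl changes the tolerated concentration at all.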